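Moving a Chlorine on the Urea Phenyl Ring

This account rests on a few compounds, and the source may have more. Where it says the series, first, only, none or still open, it means among the compounds named here.

Three urea compounds sharing one core have been measured in a functional assay on L1210 cells (Mus musculus) for inhibition, read by MTT assay, with a stated time of 72 h; on this read-out higher numbers stand for weaker inhibition and lower numbers for stronger inhibition. Compound 1 `COc1cc(NC(C)CCCNC(=O)Nc2ccc(C(F)(F)F)cc2)c2ncccc2c1` gives 7400 nM. Compound 2 `COc1cc(NC(C)CCCNC(=O)Nc2ccc(O)cc2)c2ncccc2c1` gives 21000 nM, and compound 3 `COc1cc(NC(C)CCCNC(=O)Nc2cccc(Cl)c2)c2ncccc2c1` gives 17000 nM. Compound 3 thus stands second highest of the three numbers: the step of a 1.2-fold lower number from compound 2 to compound 3 (0.09 log units; within the scatter) lies within the scatter, while the step of a 2.3-fold higher number from compound 1 to compound 3 (0.36 log units; beyond the scatter) is the larger one and lies beyond it. The step of a 2.8-fold higher number from compound 1 to compound 2 (0.45 log units; beyond the scatter) is of similar size.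

Compound 4 `COc1cc(NC(C)CCCNC(=O)Nc2ccc(Cl)cc2)c2ncccc2c1` differs from compound 3 in one place: 4-chlorophenyl in place of 3-chlorophenyl on an amide-type nitrogen. For the measured compounds named here, no measured step isolates this change alone; the step from compound 1 to compound 3 swaps both the substituent and its place, so it bears only loosely. The two steps that reach beyond the scatter both leave from compound 1, and neither points clearly toward a large effect for a 4-chlorophenyl replacing a 3-chlorophenyl. A step no larger than the scatter, expected as a 1.4-fold lower number from compound 3 to compound 4 (0.15 log units; within the scatter), seems most likely, with perhaps a slight lean toward a lower number. Compound 4 is therefore estimated at 12000 nM in this assay, within a range from 5000 nM to 30000 nM.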

Compound 4, half-maximal inhibitory concentration: 19000 nM
Beside the measured number, compound 4's estimate is 1.6-fold (0.20 log units) below it; measured number inside the range.
By their numbers in this assay, from the lowest: compound 1; then compounds 3, 4 and 2 (each within the scatter of the next).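

In this assay, moving the chlorine gives a 1.1-fold higher number from compound 3 to compound 4 (0.05 log units; within the scatter), so on this amide-type nitrogen the 3-chlorophenyl and 4-chlorophenyl groups cannot be told apart. Chloro in place of hydroxy on the same aromatic carbon gives a 1.1-fold lower number from compound 2 to compound 4 (0.04 log units; within the scatter), which is also no readable difference, while chloro in place of trifluoromethyl gives a 2.6-fold higher number from compound 1 to compound 4 (0.41 log units; beyond the scatter), so among these four compounds only compound 1 stands apart, and only modestly. Nothing measured here explains why these steps have the sizes they do. Going by these compounds, whether trifluoromethyl would keep its edge if it sat where the chlorine of compound 3 sits remains open. Also open, on these data alone, is what an amine, a carboxylic acid or a methoxy group would give on the same ring.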